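Swapping the Aryl Group on the Amine of Compound 1

A few compounds are considered here, and "the series" means these few. Any claim that something is new, unique, unknown or untested is made for them only; others in the source may bear on it.

Compound 1 `COc1cc(/C=C/C(=O)c2sc(Nc3ccccc3C)nc2C)cc(OC)c1OC` is tested in a functional assay on BGC-823 cells (Homo sapiens) for cytotoxicity, read by MTT assay (a higher number here means a weaker inhibitor, a lower number a stronger inhibitor), where compound 1 gives 5400 nM. Within the data shown here, that is the only true number among the three measured compounds. Compound 2 `COc1ccc(/C=C/C(=O)c2sc(Nc3ccc(Cl)c(Cl)c3)nc2C)cc1` reaches only the assay limit, and compound 2 shows > 25000 nM. Compound 3 `Cc1ccccc1Nc1nc(C)c(C(=O)/C=C/c2ccc(Cl)cc2)s1` likewise stops at a limit, with compound 3 at > 25000 nM. Among the measured compounds shown here, both of these rest at the limit of > 25000 nM in this assay, at which 2 of the 3 values shown sit, so compound 1 stands alone as the one quantified value. Compound 4 `COc1cc(/C=C/C(=O)c2sc(Nc3ccc(Cl)cc3)nc2C)cc(OC)c1OC` keeps the core of compound 1 and differs in a single place: 4-chlorophenyl in place of 2-methylphenyl on a nitrogen on an aromatic ring. For the measured compounds named here, no measured pair shows this exact change, so its size is uncertain. A step toward weaker inhibition, within a modest range, is expected, a 1.5-fold higher number from compound 1 to compound 4 (0.17 log units; within the scatter). Compound 4 is therefore estimated at 8000 nM, between 2500 nM and 25000 nM.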

Compound 4, half-maximal inhibitory concentration: > 25000 nM
Compound 4 ended at the assay's limit; the forecaster's own chance of this, stated with the estimate: 30%; middle value at least 3.1-fold (0.49 log units) from the limit.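

Replacing 2-methylphenyl with 4-chlorophenyl on the nitrogen gives an at least 4.6-fold higher number from compound 1 to compound 4 (0.66 log units; beyond the scatter) in this assay. This is the first step shown between two measured compounds that differ in one place, and it shows that the aryl group on this nitrogen matters. Compound 4 gives > 25000 nM, a limit of the assay and not a number, so the true size of the step stays unknown: the limit of > 25000 nM in this assay, at which 3 of the 4 values shown sit.

The compounds shown leave open whether losing the methyl or gaining the chlorine accounts for the step. A plain phenyl group on the same nitrogen would separate the two.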